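This account rests on a few compounds, and the source may have more. Where it says the series, first, only, none or still open, it means among the compounds named here.

The measured compounds and their numbers:
compound 1, `Cc1nn(C)c2c(O)nc(Cc3ccccc3)nc12`, 1310 nM
compound 2, `Cc1nn(C)c2c(O)nc(-c3ccc(Cl)cc3)nc12`, 410 nM
compound 3, `Cc1ccc(-c2nc(O)c3c(n2)c(C)nn3C)cc1`, 400 nM

In an assay on membranes from brain for binding affinity to adenosine receptor A1 (Rattus norvegicus), read by radioligand binding (a higher number here means a weaker inhibitor, a lower number a stronger inhibitor), compound 3 gives the lowest of the three numbers. Compound 2 sits nearest, its number and that of compound 3 lying within the scatter of each other, while compound 1 stands furthest away, with a higher number beyond the scatter. Compound 4, `Cc1nn(C)c2c(O)nc(-c3ccc(C(F)(F)F)cc3)nc12`, has not yet been measured. It differs from compound 3 in one place: trifluoromethyl in place of methyl on an aromatic carbon. Going by the values given here, only one measured step touches the same place: a 1.0-fold lower number from compound 2 to compound 3 (0.01 log units; within the scatter). That step shows that exchanging one group for another at this position left this assay unmoved. The change into compound 4 brings in a group with more heavy atoms than the methyl, and none of the three measured compounds speaks to such a change directly. The expectation is therefore that compound 4 stays close to compound 3, with a modest drift toward a higher number, a 1.4-fold higher number from compound 3 to compound 4 (0.14 log units; within the scatter). In this assay compound 4 is estimated at 550 nM, with a range from 200 nM to 1500 nM.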

Compound 4, half-maximal inhibitory concentration: 463 nM
Compound 4: middle estimate off by 1.2-fold (0.07 log units), on the high side; the measured number falls inside the stated range.
By their numbers in this assay, from the lowest: compounds 3, 2 and 4 (each within the scatter of the next); then compound 1.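

In this assay, trifluoromethyl in place of methyl on this aromatic carbon gives a step within the scatter (a 1.2-fold higher number from compound 3 to compound 4 (0.06 log units; within the scatter)), and the direct comparison with chloro also stays within it (a 1.1-fold higher number from compound 2 to compound 4 (0.05 log units; within the scatter)). The earlier compounds had shown only that methyl and chloro could be exchanged here without moving the number. Compounds 2, 3 and 4 now extend this to a group of 4 heavy atoms, so that all three groups on this carbon read alike in this assay.

On these data alone, whether that holds for an amine, a carboxylic acid or a longer chain such as butyl at this position remains open. No measured evidence is available to explain why these three groups read alike.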